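The source may hold more compounds than are shown below. What is called first, only, known or untested is meant among the compounds shown, and "the series" means these compounds.

Of the compounds shown here, two sharing one core have been measured so far in a functional assay on QGY-7703 cells (Homo sapiens) for cytotoxicity, read by MTT assay, with a stated time of 24 h; on this read-out higher numbers stand for weaker inhibition and lower numbers for stronger inhibition. Compound 1 `O=C1/C(=C/c2ccncc2)CN(S(=O)(=O)c2ccccc2)C/C1=C\c1ccccc1C(F)(F)F` gives 6210 nM and compound 2 `O=C1/C(=C/c2ccncc2)CN(S(=O)(=O)c2ccc([N+](=O)[O-])cc2)C/C1=C\c1ccccc1C(F)(F)F` gives 9730 nM, so compound 2 stands level with compound 1, within the scatter. Compound 3 `O=C1/C(=C/c2ccncc2)CN(S(=O)(=O)c2ccc(Br)cc2)C/C1=C\c1ccccc1C(F)(F)F` keeps that core and differs from compound 2 in one group, with bromo in place of nitro on an aromatic carbon, para to a large group (bromo in place of nitro on an aromatic carbon). Among the compounds with values here, only one measured step bears on this place. Nitro in place of hydrogen gave a 1.6-fold higher number from compound 1 to compound 2 (0.20 log units; within the scatter), which did not leave the scatter. Within the data shown here, nothing measured so far points to a real shift when bromo enters, so no step beyond the scatter is expected in this assay. The expected step is a 1.3-fold lower number from compound 2 to compound 3 (0.11 log units; within the scatter). For compound 3 the estimated value is 7500 nM, with an expected range of 3500 nM to 15000 nM.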

Compound 3, half-maximal inhibitory concentration: 7060 nM
Estimate against measurement, compound 3: 1.1-fold (0.03 log units) above; measured number inside the range.
By their numbers in this assay, from the lowest: compounds 1, 3 and 2 (each within the scatter of the next).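

In this assay bromo in place of nitro gives a 1.4-fold lower number from compound 2 to compound 3 (0.14 log units; within the scatter) and bromo in place of hydrogen gives a 1.1-fold higher number from compound 1 to compound 3 (0.06 log units; within the scatter) so neither step leaves the scatter. With a second group now tested on this aromatic carbon, para to a large group, hydrogen, nitro and bromo all stand level, and a nitro-to-bromo swap, which leaves out the nitro group's hydrogen-bond acceptors, does not separate compound 2 from compound 3 in this read-out. No supporting evidence is available to explain this result.

From the compounds shown here alone, whether an amine, a carboxylic acid or a longer chain at this place would move the number beyond the scatter remains open. So does whether this level picture would hold for the same three compounds on other cell lines or at other exposure times.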